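The source may hold more compounds than are shown below. What is called first, only, known or untested is meant among the compounds shown, and "the series" means these compounds.

Measured so far in an ADME assay on MDCK cells (Canis lupus familiaris) for cytotoxicity, read by MTT assay, with a stated time of 3 days; a higher number here means that more compound is tolerated, a lower number that less compound is tolerated:

compound 1 `CC1(C)C[C@H](O)C[C@](C)(CNc2nc3ccc(F)cc3s2)C1` gives 16200 nM
compound 2 `CC1(C)C[C@H](O)C[C@](C)(CNc2nc3ccc(Cl)cc3s2)C1` gives 4200 nM
compound 3 `CC1(C)C[C@H](O)C[C@](C)(CNc2cc(F)cc(S(N)(=O)=O)c2)C1` gives 55000 nM

Compounds 1 and 2 share a core and differ in one place, (chloro in place of fluoro on an aromatic carbon); this change gave a 3.9-fold lower number from compound 1 to compound 2 (0.59 log units; beyond the scatter). Compound 3 has a different core; how its core differs from that of compound 1 is not broken down here. Its number in this assay is the highest of the three.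

Compound 4 `CC1(C)C[C@H](O)C[C@](C)(CNc2cc(Cl)cc(S(N)(=O)=O)c2)C1` is not yet measured. It differs from compound 3 by chloro in place of fluoro on an aromatic carbon. This is the same kind of change as that from compound 1 to compound 2, but not the same: in compound 4 it sits on a ring of carbon only, meta to a large group and meta to a sulfamoyl group, while in compound 2 it sits on a ring that is part of a fused or bridged system of two rings, meta and para to a fused ring.

Resting on a 3.9-fold lower number from compound 1 to compound 2 (0.59 log units; beyond the scatter), compound 4 is expected to show a 3.7-fold lower number from compound 3 to compound 4 (0.56 log units; beyond the scatter). The estimate for compound 4 is 15000 nM, with a range from 5000 nM to 40000 nM.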

Compound 4, half-maximal cytotoxic concentration: 8400 nM
Compound 4: the middle estimate sits 1.8-fold (0.25 log units) above what was measured; the range from low to high includes it.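

In this assay, chloro in place of fluoro on an aromatic carbon of the ring of carbon only gave a 6.5-fold lower number from compound 3 to compound 4 (0.82 log units; beyond the scatter). Set beside the earlier step, the change lowered the number on both cores, and the two sizes cannot be told apart: the same change on two cores in this assay, a 3.9-fold lower number (0.59 log units; beyond the scatter) from compound 1 to compound 2 and a 6.5-fold lower number (0.82 log units; beyond the scatter) from compound 3 to compound 4, 1.7-fold (0.23 log units) apart, within the scatter of two such steps

Across these two cores, then, the change carried over in direction and, within the scatter, in size, with no pair in the series going against it; but this rests on two pairs in a single assay, so it shows neither a rule for other cores nor why the number falls.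

The compounds shown leave open whether bromo, methyl or a nitrile on the same aromatic carbon would continue the step from fluoro to chloro. They also leave open whether the step would hold with a carboxylic acid or an amine in place of the sulfamoyl group.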